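The source may hold more compounds than are shown below. What is called first, only, known or untested is meant among the compounds shown, and "the series" means these compounds.

Measured in an ADME assay on Vero cells (Chlorocebus sabaeus) for cytotoxicity, read by MTT assay, with a stated time of 72 h; on this read-out higher numbers stand for lower toxicity in this test and lower numbers for higher toxicity in this test:
compound 1 `COC(=O)c1cc(-c2cccc(NC(=O)c3ccc(/C=C/C(=O)c4cccnc4)cc3)c2)on1` — "not determined" (no result reported)
compound 2 `COC(=O)c1cc(-c2cccc(NC(=O)c3ccc(/C=C/C(=O)c4ccccc4)cc3)c2)on1` — > 50 ug/mL
compound 3 `COC(=O)c1cc(-c2cccc(NC(=O)c3ccc(/C=C/C(=O)c4ccc(OC)cc4OC)cc3)c2)on1` — > 50 ug/mL.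

Compound 1 gives "not determined" (no result reported) in this assay. For compound 2 the value > 50 ug/mL in this assay is a limit of the assay, not a number. For compound 3 the value > 50 ug/mL in this assay is likewise a limit, not a number. Compound 3 thus stands at the limit of > 50 ug/mL in this assay, at which 2 of the 3 values shown sit, with no single number to fix it. Within the data shown here, the one measured step, a step that the two limits leave unreadable from compound 2 to compound 3, cannot be sized. Compound 4 `COC(=O)c1cc(-c2cccc(NC(=O)c3ccc(/C=C/C(=O)c4ccc(CC(C)C)cc4)cc3)c2)on1` differs from compound 3 by 4-isobutylphenyl in place of 2,4-dimethoxyphenyl on a carbonyl carbon. Among the measured compounds shown here, no measured step bears on this change, so the estimated step that the limit leaves unreadable from compound 3 to compound 4 is expected to stay within the scatter. Compound 4 is expected at 60 ug/mL in this assay, within 25 ug/mL to 150 ug/mL, most likely again reported only as a limit.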

Compound 4, half-maximal cytotoxic concentration: > 10 ug/mL
Compound 4: no number, only a limit; the forecaster's own chance of this, stated with the estimate: 75%; the middle value is on the limit's open side.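

Compound 4 gives > 10 ug/mL, a limit and not a number, and no step can be read among compound 2, compound 3 and compound 4. Where the half-maximal cytotoxic concentration of each compound actually lies remains open.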